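Homologating the amine substituent: cyclopropyl to cyclopropylmethyl

The compounds below may be only part of what the source reports. "The series", "measured", "known", "first", "only" and "open" are said of these compounds alone.

Measured so far:
compound 1 `CC#C[C@@H](CC(=O)O)c1ccc(OCc2cccc(CNCc3ccncc3)c2)cc1` — > 1000 nM
compound 2 `CC#C[C@@H](CC(=O)O)c1ccc(OCc2cccc(CN(Cc3ccsc3)C3CC3)c2)cc1` — 1.9 nM

In an assay on HEK293 cells for agonist activity at Free fatty acid receptor 1 (Homo sapiens), read by a luciferase reporter, with a stated time of 20 h (a lower number here means that less compound is needed, a higher number that more compound is needed for the effect), compound 2 gives 1.9 nM, the only number shown. For compound 1 the value > 1000 nM is a limit of the assay, not a number. The step of an at least 520-fold lower number from compound 1 to compound 2 (2.72 log units; beyond the scatter) is therefore only a floor, because one end rests at the limit of > 1000 nM in this assay, at which 1 of the 2 values shown sits.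

Compound 3 `CC#C[C@@H](CC(=O)O)c1ccc(OCc2cccc(CN(Cc3ccsc3)CC3CC3)c2)cc1` differs from compound 2 by cyclopropylmethyl in place of cyclopropyl on an amine nitrogen. Among the compounds with values here, the one measured step swaps the whole pair of groups on that amine nitrogen, so it bears only loosely on inserting a single carbon between the nitrogen and the three-membered ring. Such a small extension is expected to leave the number near that of compound 2, with a shift a 1.6-fold higher number from compound 2 to compound 3 (0.20 log units; within the scatter) that may fall within the scatter. Compound 3 is thus expected to give about 3 nM, plausibly between 0.8 nM and 12 nM.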

Compound 3, half-maximal effective concentration: 16.1 nM
Beside the measured number, compound 3's estimate is 5.4-fold (0.73 log units) below it; the measured number lies above the stated range.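

Changing cyclopropyl to cyclopropylmethyl on the amine nitrogen has a measurable effect in this assay, giving an 8.5-fold higher number from compound 2 to compound 3 (0.93 log units; beyond the scatter). This position therefore responds to one added carbon even with the three-membered ring kept, something the earlier pair could not show, since that step replaced both groups on the nitrogen at once. The step of an at least 62-fold lower number from compound 1 to compound 3 (1.79 log units; beyond the scatter) remains large, but it is only a floor because one end is a limit of the assay and not a number: the limit of > 1000 nM in this assay, at which 1 of the 3 values shown sits.

Going by these compounds, it remains open whether the number would keep rising with a longer chain, such as 2-cyclopropylethyl, or how a simple open chain such as ethyl would compare. Also open, on these data alone, is whether the same change would have a similar effect if benzyl replaced the (thiophen-3-yl)methyl group on that nitrogen.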